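Shortening the Side Chain and Swapping Phenyl for Thiophene

This account rests on a few compounds, and the source may have more. Where it says the series, first, only, none or still open, it means among the compounds named here.

Three measured compounds share one core. Compound 1 `CC(=O)Nc1ccc([C@H](C)NCC2CCN(CCCc3c[nH]c4ccc(-n5cnnc5)cc34)CC2)cc1` gives 9.3 nM in an assay on CHO cells for displacement of a labelled ligand from 5-hydroxytryptamine receptor 1B (Homo sapiens); on this read-out lower numbers stand for stronger inhibition and higher numbers for weaker inhibition. Compound 2 `C[C@@H](NCC1CCN(CCCc2c[nH]c3ccc(-n4cnnc4)cc23)CC1)c1ccccc1` gives 14 nM in this assay, and compound 3 `CC(=O)Nc1ccc(CNCC2CCN(CCCc3c[nH]c4ccc(-n5cnnc5)cc34)CC2)cc1` gives 8.9 nM. Compound 2 has the highest of the three numbers, but the gaps are small: a 1.5-fold higher number from compound 1 to compound 2 (0.18 log units; within the scatter), and a 1.6-fold lower number from compound 2 to compound 3 (0.20 log units; within the scatter). Compound 4 `CN(Cc1cccs1)C1CCN(CCCc2c[nH]c3ccc(-n4cnnc4)cc23)CC1` is not yet measured; it differs from compound 2 by methyl((thiophen-2-yl)methyl)amino in place of ((1-phenylethyl)amino)methyl on a saturated ring carbon. Among the compounds with values here, no measured step alters this part of the molecule so deeply; the steps so far, including a 1.0-fold lower number from compound 1 to compound 3 (0.02 log units; within the scatter), only show that modest changes to the group on the amine stay within the scatter. Compound 4 is therefore expected to give 30 nM, between 8 nM and 120 nM. That estimate means a step of a 2.1-fold higher number from compound 2 to compound 4 (0.33 log units; beyond the scatter).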

Compound 4, half-maximal inhibitory concentration: 140 nM
For compound 4 the middle estimate is 4.7-fold (0.67 log units) below the measured one; the whole stated range lies below it.
By their numbers in this assay, from the lowest: compounds 3, 1 and 2 (each within the scatter of the next); then compound 4.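

The earlier changes to the group on the amine all stayed within the scatter, but putting methyl((thiophen-2-yl)methyl)amino in place of ((1-phenylethyl)amino)methyl on the saturated ring carbon brings a 10-fold higher number from compound 2 to compound 4 (1.00 log units; beyond the scatter) in this assay and so goes beyond it. This position therefore does not accept every replacement. No supporting measurement explains the rise.

The swap alters the aromatic ring, the hydrogen-bond donor count and the link to the ring carbon all at once. The compounds shown leave open which of these matters, and a benzyl(methyl)amino group on that carbon would separate the thiophene from the other changes.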